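Changing the amide substituent of compound 1

A few compounds are considered here, and "the series" means these few. Any claim that something is new, unique, unknown or untested is made for them only; others in the source may bear on it.

Within the data shown here, in an ADME assay on MT4 cells (Homo sapiens) for cytotoxicity, read by MTT assay (on this read-out higher numbers stand for lower toxicity in this test and lower numbers for higher toxicity in this test), compound 1 (`Cc1cc(C)cc(S(=O)(=O)c2c(C(=O)Nc3ccncc3)[nH]c3ccc(Cl)cc23)c1`) gives 20200 nM, the only actual number so far. Compound 2 (`Cc1cccc(C)c1S(=O)(=O)c1c(C(N)=O)[nH]c2ccc(Cl)cc12`) reads > 48900 nM, which is a limit of the assay. Compound 3 (`Cc1cc(C)cc(S(=O)(=O)c2c(C(=O)NCc3cccs3)[nH]c3ccc(Cl)cc23)c1`) keeps the core of compound 1 but carries (thiophen-2-yl)methyl in place of pyridin-4-yl on an amide-type nitrogen. Among the measured compounds shown here, no measured step covers this change, so no shift beyond the scatter is expected in this assay. The expected step is a 1.3-fold lower number from compound 1 to compound 3 (0.13 log units; within the scatter). For compound 3 the estimated value is 15000 nM, within an expected range of 5000 nM to 45000 nM.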

Compound 3, half-maximal cytotoxic concentration: 54500 nM
For compound 3 the middle estimate is 3.6-fold (0.56 log units) below the measured one; the measured number lies above the stated range.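

Putting (thiophen-2-yl)methyl in place of pyridin-4-yl on an amide-type nitrogen gives a 2.7-fold higher number from compound 1 to compound 3 (0.43 log units; beyond the scatter) in this assay, so this position can move the read-out towards lower toxicity in this test. Both groups have the same heavy-atom count, yet the change alters the ring and the link to the nitrogen together, and this one pair cannot separate them. The read-out also has a limit in this series: the limit of > 48900 nM in this assay, at which 1 of the 3 values shown sits.

Going by these compounds, whether the ring or the link carries the step stays open. (Pyridin-4-yl)methyl or thiophen-2-yl on the same nitrogen would separate the two.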